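Amide side-chain swap on the methoxy coumarin amide

A few compounds are considered here, and "the series" means these few. Any claim that something is new, unique, unknown or untested is made for them only; others in the source may bear on it.

Among the measured compounds shown here, compound 1 `COc1cccc2cc(C(=O)NCC(=O)O)c(=O)oc12` stands highest of the two compounds measured so far in an assay on HEK293 cells for displacement of a labelled ligand from adenosine receptor A2b (Homo sapiens), read by scintillation counting, with a stated time of 30 min, tested at 10 uM (on this read-out higher numbers stand for more inhibition at the one concentration tested (going by the name of the read-out) and lower numbers for less inhibition), where compound 1 gives 35%. For the measured compounds named here, its nearest neighbour is compound 2 `O=C(O)CNC(=O)c1cc2ccccc2oc1=O`, which gives 9% in this assay; the step of a number 26 percentage points lower from compound 1 to compound 2 (beyond the scatter) is the only measured change in the set and concerns hydrogen in place of methoxy on an aromatic carbon.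

Compound 3 `COCCNC(=O)c1cc2cccc(OC)c2oc1=O` keeps the methoxy of compound 1 and differs from it elsewhere: methoxymethyl in place of carboxy on a saturated chain carbon bound to an amide-type nitrogen. Going by the values given here, no measured pair in the set touches the carboxy or the chain bound to the amide-type nitrogen, so the one known step does not bear on this change directly; it only shows that the methoxy retained in compound 3 goes with the higher of the two numbers seen. The expected size of the step is therefore open, with a modest fall or rise equally possible and a step within the scatter the default. For compound 3 the estimate in this assay is 30%, with a range from 5% to 60%, meaning an expected step of a number 5 percentage points lower from compound 1 to compound 3 (within the scatter).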

Compound 3, a percentage reported as inhibition, at one concentration (the size of the read-out at that concentration, not a potency): 18%
The estimate for compound 3 lay 12 percentage points above the measured number, within the range that was stated.
By their numbers in this assay, from the lowest: compounds 2 and 3 (each within the scatter of the next); then compound 1.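

In this assay, the side chain turns out to count as well: with the methoxy of compound 1 kept in place, methoxymethyl in place of carboxy on the saturated chain carbon bound to an amide-type nitrogen gives a number 17 percentage points lower from compound 1 to compound 3 (beyond the scatter). The series therefore has a second place where a single change moves the number beyond the scatter, besides the aromatic carbon that carries the methoxy, and at this second place the carboxy goes with the higher number of the pair. Carboxy carries a hydrogen-bond donor and methoxymethyl carries none, but nothing available gives a reason for the step, and this one pair cannot tie it to that count.

Still open, from the compounds shown here alone, is whether a different group on the same chain carbon, such as an amine, a hydroxyl or a primary amide, would stay with compound 1 or fall with compound 3, and whether a longer chain ending in a carboxylic acid would hold the number. Also open, going by these compounds, is whether the carboxy and the methoxy act independently on the shared core, which would take a pair changing the side chain with hydrogen in place of methoxy.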